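The source may report more compounds than this note shows. Statements on the series, on what has been measured and on what is new or still open speak of the compounds shown alone.

Of the compounds shown here, two sharing one core have been tested so far. Compound 1 `O=C(Nc1nn[nH]n1)c1cc(Br)ccn1` stands highest of the two in a functional assay on the whole organism for inhibition, with Rattus norvegicus as the target, at a dose of 3 mg/kg by the oral route (on this read-out higher numbers stand for a stronger effect at the one dose given and lower numbers for a weaker effect), where compound 1 gives 34%. Compound 2 `O=C(Nc1nn[nH]n1)c1cccc(Cl)n1` gives 18% in this assay, a gap beyond the usual scatter.

Compound 3 `CCCCc1ccnc(C(=O)Nc2nn[nH]n2)c1` has not yet been measured. It differs from compound 1 by butyl in place of bromo on an aromatic carbon. Among the measured compounds shown here, no measured pair shows a change of this kind, so only a small step, or none beyond the scatter, is expected, amounting to an estimated a number 4 percentage points lower from compound 1 to compound 3 (within the scatter). Compound 3 is therefore expected to give about 30%, within a range from 10% to 50%.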

Compound 3, a percentage reported as inhibition, in the whole organism at one dose (the size of the read-out at that dose, not a potency): 33%
Estimate against measurement, compound 3: 3 percentage points below; measured number inside the range.
By their numbers in this assay, from the lowest: compound 2; then compounds 3 and 1 (each within the scatter of the next).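

In this assay, putting butyl in place of bromo on this aromatic carbon, opposite the ring nitrogen, gives a number 1 percentage points lower from compound 1 to compound 3 (within the scatter) and so leaves the read-out essentially unmoved. Among the compounds shown here, this position therefore takes a chain of 4 heavy atoms as readily as a single bromine, at least at this one oral dose, which the earlier compounds could not show. Nothing measured here explains why these two groups read alike.

From the compounds shown here alone, whether an amine, a carboxylic acid or a longer chain such as octyl would hold this level at the same position remains open.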